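The compounds below may be only part of what the source reports. "The series", "measured", "known", "first", "only" and "open" are said of these compounds alone.

Measured so far:
compound 1, `O=C(O)Cc1sc(Cc2ccccc2)nc1-c1ccc(Cl)cc1`: 50%
compound 2, `O=C(O)Cc1sc(C(c2ccc(F)cc2)c2ccc(F)cc2)nc1-c1ccc(Cl)cc1`: 80%

Two compounds share the core that carries the acetic acid and the chlorophenyl group. In an in vitro functional assay on HEK285-7 cells for antagonist activity at prostaglandin D2 receptor 2 (Homo sapiens), read by BRET and beta-arrestin recruitment (a lower number here means a smaller maximal response, a higher number a larger maximal response), compound 1 gives 50%, while compound 2 gives 80%, the higher of the two numbers, with compound 1 lying lower by more than the usual scatter. Compound 3, `O=C(O)Cc1sc(C(c2ccccc2)c2ccc(F)cc2)nc1-c1ccc(Cl)cc1`, keeps the diaryl methyl group of compound 2 but with one change: hydrogen in place of fluoro on an aromatic carbon. Within the data shown here, with no step between measured compounds at hand for this change, the size of the step in this assay is uncertain; a small loss of maximal response, at most near the edge of the scatter, is the expectation, because compound 2 gives 80% and compound 1, with no fluorophenyl at all, gives 50%. Compound 3 is accordingly expected to show a step of a number 6 percentage points lower from compound 2 to compound 3 (within the scatter). Compound 3 is estimated at 74%, within 60% to 88%.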

Compound 3, largest response reached (reported as efficacy), in percent of the reference or control that the assay uses: 80%
For compound 3 the middle estimate is 6 percentage points below the measured one; low and high end bracket the measured number.
By their numbers in this assay, from the lowest: compound 1; then compounds 2 and 3 (each within the scatter of the next).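

In this assay the change from 4-fluorophenyl to phenyl gives no change at the digits printed from compound 2 to compound 3 (within the scatter) and so leaves the maximal response in place: on this aromatic carbon, para to a large group, hydrogen and fluoro cannot be told apart. The larger difference comes with the other change, 4-fluorophenyl in place of hydrogen on a saturated chain carbon bound to two aromatic carbons, which gives a number 30 percentage points higher from compound 1 to compound 3 (beyond the scatter) and shows that this response can move with the group on that carbon. No measurement at hand speaks to the reason for either step.

From the compounds shown here alone, whether a methoxy group, an amine or a nitrile at this aromatic carbon would also leave the response in place remains open. So does the effect of removing the fluoro from the remaining 4-fluorophenyl, which would leave two phenyl groups on the chain carbon.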